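The source may report more compounds than this note shows. Statements on the series, on what has been measured and on what is new or still open speak of the compounds shown alone.

Three triazenes have been run through an ADME assay on Vero cells (Chlorocebus sabaeus) for cytotoxicity, read by crystal violet staining; a higher number here means that more compound is tolerated, a lower number that less compound is tolerated. Compound 1 `O=[N+]([O-])c1cccc(/N=N/N2CCCCC2)c1` gives 83000 nM. Compound 2 `CN(C)CCCN(/N=N/c1c(F)cccc1F)c1ccccc1` gives 25000 nM, and compound 3 `Cc1ccc(/N=N/c2ccc(NCCCN(C)C)cc2)cc1` gives 50000 nM. Compound 1 has the highest of the three numbers: compound 3 sits within the scatter of it, while compound 2 lies beyond the scatter on the lower side.

Compound 4 `c1ccc(/N=N/N2CCCCC2)cc1` is not yet measured in this assay . It differs from compound 1 by hydrogen in place of nitro on an aromatic carbon. Among the compounds with values here, no step between measured compounds isolates this change, so nothing in the set says how much the nitro group contributes; the expectation is a step of a 1.2-fold lower number from compound 1 to compound 4 (0.07 log units; within the scatter), which is no more than the scatter in either direction. Compound 4 is therefore estimated at 70000 nM, within 30000 nM to 160000 nM.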

Compound 4, half-maximal cytotoxic concentration: > 100000 nM
Compound 4: only a limit was reported (the forecaster's own chance of this, stated with the estimate: 15%); middle value at least 1.4-fold (0.15 log units) from the limit.
By their numbers in this assay, from the lowest: compounds 2, 3 and 1 (each within the scatter of the next, the first and the last beyond it). At a limit, above all of these: compound 4.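

Hydrogen in place of nitro on the aromatic carbon gives the first one-place comparison in the series: in this assay it is an at least 1.2-fold higher number from compound 1 to compound 4 (0.08 log units; that floor lies within the scatter). Compound 4 gives > 100000 nM, which is a limit of the assay and not a number: the limit of > 100000 nM in this assay, at which 1 of the 4 values shown sits. Loss of the nitro group therefore brings no fall in the tolerated concentration, but the true size of the step remains unfixed.

From the compounds shown here alone, whether an amine, a carboxylic acid or a methyl group on that aromatic carbon would shift the number in this assay stays open.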